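This account rests on a few compounds, and the source may have more. Where it says the series, first, only, none or still open, it means among the compounds named here.

Compound 2 `CS(=O)(=O)c1ccc(C(=O)N2CCC(n3cncc3-c3ccc(OS(=O)(=O)c4cccc5cnccc45)cc3)CC2)cc1` gives 25 nM in an assay on HEK293 cells for antagonist activity at P2X purinoceptor 7 (Homo sapiens), read by fluorescence, with a stated time of 2 h (on this read-out higher numbers stand for weaker inhibition and lower numbers for stronger inhibition), the lowest of the three measured numbers. Compound 1 `O=C(c1ccc(Oc2ccccc2)cc1)N1CCC(n2cncc2-c2ccc(OS(=O)(=O)c3cccc4cnccc34)cc2)CC1` gives 187 nM, and compound 3 `CC(C)(O)c1ccc(C(=O)N2CCC(n3cncc3-c3ccc(OS(=O)(=O)c4cccc5cnccc45)cc3)CC2)cc1` gives 109 nM. The measured steps are a 7.5-fold lower number from compound 1 to compound 2 (0.87 log units; beyond the scatter), a 1.7-fold lower number from compound 1 to compound 3 (0.23 log units; within the scatter) and a 4.4-fold higher number from compound 2 to compound 3 (0.64 log units; beyond the scatter); each of them swaps a group on an aromatic carbon of the shared core and leaves the sulfonyl side untouched. Compound 4 `CS(=O)(=O)c1ccc(C(=O)N2CCC(n3cncc3-c3ccc(OS(=O)(=O)c4cccc(C(=O)NC5CC5)c4)cc3)CC2)cc1` differs from compound 2 by 3-(cyclopropylcarbamoyl)phenyl in place of isoquinolin-5-yl on a sulfonyl sulfur. Going by the values given here, no measured step bears on this change, so the expectation rests only on the spread of the three numbers. The step from compound 2 to compound 4 is expected to be a 2.4-fold higher number from compound 2 to compound 4 (0.38 log units; beyond the scatter). Compound 4 is therefore estimated at 60 nM, within a range from 15 nM to 250 nM.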

Compound 4, half-maximal inhibitory concentration: 400 nM
Compound 4: middle estimate off by 6.7-fold (0.82 log units), on the low side; measured number above the stated range.
By their numbers in this assay, from the lowest: compound 2; then compounds 3 and 1 (each within the scatter of the next); then compound 4.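

Going by these compounds alone, changing the group on the sulfonyl sulfur, which the earlier compounds left untouched, gives a 16-fold higher number from compound 2 to compound 4 (1.20 log units; beyond the scatter), a larger step than any seen on the aromatic carbon. This position therefore does not take every aromatic group equally: 3-(cyclopropylcarbamoyl)phenyl reads far worse than isoquinolin-5-yl. Nothing shown here gives a reason for the step. A single swap cannot separate the loss of the isoquinolin-5-yl ring system from the arrival of the cyclopropylcarbamoyl group. Going by these compounds, how a plain phenyl or a 3-carboxyphenyl would read on this sulfur remains open.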